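A 3-Hydroxypropoxy Group Replaces an Aminopropylamino Group

This account rests on a few compounds, and the source may have more. Where it says the series, first, only, none or still open, it means among the compounds named here.

In an ADME assay on the whole organism (serum) with Homo sapiens as the target (on this read-out higher numbers stand for a longer-lived compound and lower numbers for a shorter-lived compound), compound 3 `Cc1cn(C2CC(N=[N+]=[N-])C(COC(=O)NCCCN)O2)c(=O)[nH]c1=O` gives > 48 h, which is only a limit. This is the limit of > 48 h in this assay, at which 2 of the 3 values shown sit. Compound 1 `Cc1cn(C2CC(N=[N+]=[N-])C(COC(=O)NCCCO)O2)c(=O)[nH]c1=O` gives > 48 h, also a limit. Going by the values given here, the one measured step, a step that the two limits leave unreadable from compound 1 to compound 3, therefore offers no size to carry over. The change to compound 4 `Cc1cn(C2CC(N=[N+]=[N-])C(COC(=O)OCCCO)O2)c(=O)[nH]c1=O` puts 3-hydroxypropoxy in place of (3-aminopropyl)amino on a carbonyl carbon. The closest guide is compound 2 `Cc1cn(C2CC(N=[N+]=[N-])C(COC(=O)OCCCC(=O)OC(C)(C)C)O2)c(=O)[nH]c1=O`, which also has an oxygen rather than a nitrogen on that carbonyl carbon and gives 0.267 h in this assay. A large fall towards shorter life is therefore expected, an at least 32-fold lower number from compound 3 to compound 4 (1.50 log units; beyond the scatter). For compound 4 the estimated half-life is 1.5 h, with an expected range of 0.2 h to 10 h.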

Compound 4, half-life: 0.167 h
For compound 4 the middle estimate is 9.0-fold (0.95 log units) above the measured one, and the stated range ends above it.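

In this assay, the oxygen in place of the nitrogen on the carbonyl carbon now has a measured size: an at least 280-fold lower number from compound 1 to compound 4 (2.45 log units; beyond the scatter), a comparison in which both chains end in hydroxy. The step with the amine-ended chain is of the same printed size, an at least 280-fold lower number from compound 3 to compound 4 (2.45 log units; beyond the scatter). With oxygen on that carbonyl carbon, the other chain ending makes no difference beyond the scatter: a 1.6-fold lower number from compound 2 to compound 4 (0.20 log units; within the scatter).

The compounds shown leave open how an amine in place of the hydroxy of 3-hydroxypropoxy would read, and whether a longer chain would shift the half-life.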